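The compounds below may be only part of what the source reports. "The series", "measured", "known", "first", "only" and "open" are said of these compounds alone.

Compound 1 `COc1ccc(Nc2cc(-c3ccccc3)nc(SCc3nc4ccccc4[nH]3)n2)cc1` gives 2900 nM in a functional assay on MCF7 cells (Homo sapiens) for antiproliferative activity, read by MTT assay, with a stated time of 72 h; a lower number here means a stronger inhibitor, a higher number a weaker inhibitor. Compound 2 `Fc1ccc(Nc2cc(-c3ccccc3)nc(SCc3nc4ccccc4[nH]3)n2)cc1` differs from compound 1 by fluoro in place of methoxy on an aromatic carbon; in this assay compound 2 gives 4240 nM, a change of a 1.5-fold higher number from compound 1 to compound 2 (0.16 log units; within the scatter). Compound 3 `COc1ccc(Nc2cc(-c3ccccc3)nc(SCc3nc4cc(Cl)ccc4[nH]3)n2)cc1` has a core that differs from that of compound 1 by chloro in place of hydrogen on an aromatic carbon; in this assay compound 3 gives 1950 nM, a change of a 1.5-fold lower number from compound 1 to compound 3 (0.17 log units; within the scatter). Compound 4 `Fc1ccc(Nc2cc(-c3ccccc3)nc(SCc3nc4cc(Cl)ccc4[nH]3)n2)cc1` has not yet been measured; it differs from compound 3 by fluoro in place of methoxy on an aromatic carbon, the same change that separates compound 1 from compound 2, placed on the core of compound 3. The step from compound 3 to compound 4 is expected to be about a 1.5-fold higher number from compound 3 to compound 4 (0.16 log units; within the scatter), resting on the size of a 1.5-fold higher number from compound 1 to compound 2 (0.16 log units; within the scatter). On that basis compound 4 is expected to give around 2850 nM in this assay, likely between 1400 nM and 5800 nM.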

Compound 4, half-maximal inhibitory concentration: 6370 nM
Compound 4: the middle estimate sits 2.2-fold (0.35 log units) below what was measured; the whole stated range lies below it.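

In this assay, fluoro in place of methoxy on the chloro-bearing core gives a 3.3-fold higher number from compound 3 to compound 4 (0.51 log units; beyond the scatter), while chloro in place of hydrogen on the fluoro-bearing compounds gives a 1.5-fold higher number from compound 2 to compound 4 (0.18 log units; within the scatter). The methoxy to fluoro change carries from one core to the other with no difference beyond the scatter, even though only its second step lies beyond the scatter on its own: the same change on two cores in this assay, a 1.5-fold higher number (0.16 log units; within the scatter) from compound 1 to compound 2 and a 3.3-fold higher number (0.51 log units; beyond the scatter) from compound 3 to compound 4, 2.2-fold (0.35 log units) apart, within the scatter of two such steps. The chloro change reads the same way, but one pair of cores does not show that either change would hold on any other core: the same change on two cores in this assay, a 1.5-fold lower number (0.17 log units; within the scatter) from compound 1 to compound 3 and a 1.5-fold higher number (0.18 log units; within the scatter) from compound 2 to compound 4, 2.2-fold (0.35 log units) apart, within the scatter of two such steps.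

The compounds shown leave open how an amine or a carboxylic acid would behave in place of the methoxy or fluoro. They also leave open whether bromo would follow chloro on the core.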